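A hydroxy group added to compound 1

The compounds below may be only part of what the source reports. "The series", "measured", "known", "first", "only" and "open" are said of these compounds alone.

Measured in a functional assay on WRL68 cells (Homo sapiens) for cytotoxicity, read by MTT assay, with stated times of 6 h and 48 h; on this read-out lower numbers stand for stronger inhibition and higher numbers for weaker inhibition:
Compound 1 `Cn1c(/C=C/C(=O)c2ccccc2)cc(Br)c1Br`: >= 100000 nM, a limit
Compound 2 `Cn1c(/C=C/C(=O)c2ccc[nH]2)cc(Br)c1Br`: 2110 nM
Compound 3 `Cn1c(/C=C/C(=O)c2cccc(O)c2)cc(Br)c1Br`: >= 100000 nM, a limit

Compound 1 gives only a limit, >= 100000 nM, and this is the limit of >= 100000 nM in this assay, at which 2 of the 3 values shown sit.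

Compound 4 `Cn1c(/C=C/C(=O)c2ccc(O)cc2)cc(Br)c1Br` differs from compound 1 by one change: hydroxy in place of hydrogen on an aromatic carbon. The nearest measured change is also hydroxy in place of hydrogen on an aromatic carbon, and it gave a step that the two limits leave unreadable from compound 1 to compound 3. The other measured change, an at least 47-fold lower number from compound 1 to compound 2 (1.67 log units; beyond the scatter), is a different swap, 1H-pyrrol-2-yl in place of phenyl, and says little here. In this assay, a value near the limit is therefore expected, with at most a modest move towards lower numbers. The expected change is an at least 1.4-fold lower number from compound 1 to compound 4 (0.15 log units; that floor lies within the scatter). The estimate for compound 4 is 70000 nM, with an expected range of 15000 nM to 100000 nM.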

Compound 4, half-maximal inhibitory concentration: 1910 nM
Compound 4: the middle estimate sits 37-fold (1.56 log units) above what was measured, and the stated range ends above it.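

Para to a large group on the six-membered aromatic ring, hydroxy in place of hydrogen gives a readable change in this assay: an at least 52-fold lower number from compound 1 to compound 4 (1.71 log units; beyond the scatter). Compound 3 carries its hydroxy elsewhere on that ring and gives only a limit, >= 100000 nM. Its step from compound 1 cannot be read because both values are limits: the limit of >= 100000 nM in this assay, at which 2 of the 4 values shown sit.

As far as these compounds go, whether this drop needs hydroxy itself remains open. A methoxy group, an amine or a carboxylic acid at the same place would help to show that.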